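Removing the Bromine from the Triazole Aryl Group

A few compounds are considered here, and "the series" means these few. Any claim that something is new, unique, unknown or untested is made for them only; others in the source may bear on it.

Measured so far:
compound 1 `C=C1C(=O)[C@]23C[C@@]1(O)CC[C@H]2c1ccc(O)c(C)c1[C@@H]3Cn1cc(-c2ccc(Br)cc2)nn1` — 1300 nM
compound 2 `C=C1C(=O)[C@]23C[C@@]1(O)CC[C@H]2c1ccc(OS(=O)(=O)c2ccc(C)cc2)c(C)c1[C@@H]3Cn1cc(-c2ccc(Br)cc2)nn1` — 4320 nM

Of the compounds shown here, two have been tested in a functional assay on SMMC-7721 cells (Homo sapiens) for cytotoxicity, read by MTT assay, with a stated time of 4 days; on this read-out higher numbers stand for weaker inhibition and lower numbers for stronger inhibition. Compound 1 gives 1300 nM, the lowest of the two numbers. Compound 2 gives 4320 nM. Among the measured compounds shown here, the single step between them, a 3.3-fold higher number from compound 1 to compound 2 (0.52 log units; beyond the scatter), comes from putting a (4-methylphenyl)sulfonyl in place of hydrogen on the phenolic oxygen, and so it concerns a different part of the shared core than the change now at hand.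

Compound 3 `C=C1C(=O)[C@]23C[C@@]1(O)CC[C@H]2c1ccc(O)c(C)c1[C@@H]3Cn1cc(-c2ccccc2)nn1` is compound 1 with one alteration: hydrogen in place of bromo on an aromatic carbon. For the measured compounds named here, no measured step touches this position; the step from compound 1 to compound 2 speaks only to the oxygen and says nothing about the bromo on the aryl ring of the triazole. With nothing to pull the number in either direction, compound 3 is expected to sit close to compound 1, with the step of a 1.4-fold higher number from compound 1 to compound 3 (0.14 log units; within the scatter) likely within the scatter. The estimate for compound 3 is therefore 1800 nM, expected to fall between 700 nM and 4500 nM.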

Compound 3, half-maximal inhibitory concentration: 1320 nM
Compound 3: middle estimate off by 1.4-fold (0.13 log units), on the high side, and the stated range covers the measured number.
By their numbers in this assay, from the lowest: compounds 1 and 3 (each within the scatter of the next); then compound 2.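

In this assay, replacing 4-bromophenyl with phenyl gives a 1.0-fold higher number from compound 1 to compound 3 (0.01 log units; within the scatter), so the bromo on this aromatic carbon, para to a large group, can give way to hydrogen with no change beyond the scatter. Among the compounds shown here, this is the first reading at this part of the molecule, and it differs from the change on the phenolic oxygen, where the (4-methylphenyl)sulfonyl step gave a 3.3-fold higher number from compound 1 to compound 2 (0.52 log units; beyond the scatter), which is beyond the scatter. The pair shows only that the read-out in these cells is the same with bromo and with hydrogen at this place, and no measurement of any property of these compounds accompanies the result to account for that.

Both compounds leave open whether a group other than bromo or hydrogen at this place, such as an amine, a methoxy group or a carboxylic acid, would move the number at all. They also leave open whether the (4-methylphenyl)sulfonyl on the oxygen would have the same effect on compound 3, which carries the phenyl, as it has on compound 1, which carries the 4-bromophenyl.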